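The source may report more compounds than this note shows. Statements on the series, on what has been measured and on what is new or still open speak of the compounds shown alone.

Working notes on the series, all read in a functional assay on HOS-TE85 cells (Homo sapiens) for inhibition, read by CCK-8 assay, with a stated time of 72 h; a lower number here means a stronger inhibitor, a higher number a weaker inhibitor. Compound 1 (`COc1ccc(F)cc1N1C(=O)CSC1c1cccc(C(=O)NCCCCn2cccn2)c1`) gives 97.3 nM and compound 2 (`O=C(NCCCCn1cccn1)c1cccc(C2SCC(=O)N2c2ccccn2)c1`) gives 60.3 nM here. Compound 3 (`Cc1ccnc(N2C(=O)CSC2c2cccc(C(=O)NCCCCn3cccn3)c2)c1`) gives 19.6 nM and holds the lowest number of the three. Compound 4 (`O=C(NCCCCn1cccn1)c1cccc(C2SCC(=O)N2c2cccc(C3CC3)c2)c1`) carries 3-cyclopropylphenyl in place of 4-methylpyridin-2-yl on an amide-type nitrogen in a ring.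

Within the data shown here, three measured steps bear on this change at that nitrogen. Among the measured compounds shown here, compound 1 is the only measured compound with a substituted phenyl there, and the closest precedent is a 5.0-fold lower number from compound 1 to compound 3 (0.70 log units; beyond the scatter) in the direction that favours the 4-methylpyridin-2-yl group. The added methyl accounts for a 3.1-fold lower number from compound 2 to compound 3 (0.49 log units; beyond the scatter) on its own, while a 1.6-fold lower number from compound 1 to compound 2 (0.21 log units; within the scatter) separates the other two groups. For the measured compounds named here, no measured compound carries a cyclopropyl group, so the size of the step remains uncertain.

In this assay the estimated step is a 2.3-fold higher number from compound 3 to compound 4 (0.36 log units; beyond the scatter) and so a modest one towards a higher number. For compound 4 the expected value is 45 nM with an estimated range of 14 nM to 150 nM for repeated measurements.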

Compound 4, half-maximal inhibitory concentration: 299 nM
For compound 4 the middle estimate is 6.6-fold (0.82 log units) below the measured one, outside the stated range (above it).
By their numbers in this assay, from the lowest: compound 3; then compounds 2 and 1 (each within the scatter of the next); then compound 4.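

In this assay, 3-cyclopropylphenyl on the amide-type nitrogen in the ring gives the highest number of the four compounds, with a large step from the best group so far (a 15-fold higher number from compound 3 to compound 4 (1.18 log units; beyond the scatter)). Among these compounds, the position therefore separates its groups more widely than the earlier compounds showed, and the new group also stands apart from pyridin-2-yl (a 5.0-fold higher number from compound 2 to compound 4 (0.70 log units; beyond the scatter)) and from 5-fluoro-2-methoxyphenyl (a 3.1-fold higher number from compound 1 to compound 4 (0.49 log units; beyond the scatter)), so a phenyl ring alone does not fix the number, as compound 1 lies within the scatter of compound 2. No evidence here accounts for the size of these steps.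

The compounds shown leave open whether the rise goes with the cyclopropyl group or with the carbon-only ring. Unsubstituted phenyl, or pyridin-2-yl carrying cyclopropyl, would separate the two.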